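The source may report more compounds than this note shows. Statements on the series, on what has been measured and on what is new or still open speak of the compounds shown alone.

Values in an ADME assay on liver (Homo sapiens) for metabolic stability, read by LC-MS, using microsomes and NADPH; a lower number here means that less of the compound is left, a higher number that more of the compound is left:
- compound 1 `Cc1cc(CN(C)C(CC(=O)O)c2ccc(Cl)cc2)ccc1OCCn1c(=O)ccn(C)c1=O`: 76%
- compound 2 `CCN(Cc1ccc(OCCn2c(=O)ccn(C)c2=O)c(C)c1)C(CC(=O)O)c1ccc(Cl)cc1`: 46%
- compound 3 `Cc1cc(CN(CC2CC2)C(CC(=O)O)c2ccc(Cl)cc2)ccc1OCCn1c(=O)ccn(C)c1=O`: 32%

Compound 3 has the lowest number of the three, and it is separated from both others by more than the scatter: a number 44 percentage points lower from compound 1 to compound 3 (beyond the scatter), a large step, and a number 14 percentage points lower from compound 2 to compound 3 (beyond the scatter), a modest one.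

The next comparison is compound 4 `Cc1cc(CN(C2CCC2)C(CC(=O)O)c2ccc(Cl)cc2)ccc1OCCn1c(=O)ccn(C)c1=O`, which carries cyclobutyl in place of cyclopropylmethyl on an amine nitrogen.

The three measured steps bear on this change only indirectly. Besides the two above, there is a number 30 percentage points lower from compound 1 to compound 2 (beyond the scatter), also modest. Among the compounds with values here, each of them brings a larger group onto the saturated chain carbon bound to the amine nitrogen, and in each the number falls, with no compound of the three going against this. Within the data shown here, the change to compound 4 is of another kind, a rearrangement of the same atoms, and no measured step swaps one ring for another. No clear direction follows from the data, so no step beyond the scatter is expected in this assay.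

The expected change is a number 4 percentage points higher from compound 3 to compound 4 (within the scatter). For compound 4 the estimated value is 36%, with an expected range of 20% to 54%.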

Compound 4, percent of the compound remaining: 20%
For compound 4 the middle estimate is 16 percentage points above the measured one; measured number inside the range.
By their numbers in this assay, from the lowest: compound 4; then compound 3; then compound 2; then compound 1.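

In this assay, the group on the amine nitrogen matters beyond its atoms: cyclobutyl and cyclopropylmethyl have the same atoms, joined differently, yet the swap gives a number 12 percentage points lower from compound 3 to compound 4 (beyond the scatter). Cyclobutyl also extends the fall seen with the other groups at this position, with a number 26 percentage points lower from compound 2 to compound 4 (beyond the scatter) and a number 56 percentage points lower from compound 1 to compound 4 (beyond the scatter), so the numbers now run down through methyl, ethyl, cyclopropylmethyl and cyclobutyl, and none of the four compounds goes against this order. No measurement at hand speaks to what lies behind these steps.

Open, on these data alone, is where isopropyl or cyclopropyl on the same amine nitrogen would fall in this order, and so whether the ring in cyclobutyl or the branching at the carbon bound to the nitrogen goes with the lower number. Also open, as far as these compounds go, is whether an oxetanyl group at this position would stay near compound 4 in this assay or come back towards compound 1 at 76%.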